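The source may hold more compounds than are shown below. What is called first, only, known or untested is meant among the compounds shown, and "the series" means these compounds.

Measured compounds:
compound 1 `COc1cccc(/C=C/C(=O)/C=C/c2ccc(OCc3cn(CCCCCOc4cc(=O)oc5ccccc45)nn3)c(OC)c2)c1`, which in a functional assay on COLO 205 cells (Homo sapiens) for inhibition, read by sulforhodamine B assay, with a stated time of 48 h, tested at 50 uM (a lower number here means less inhibition of growth, a higher number more inhibition of growth at the concentration tested), gives 34%
compound 2 `COc1ccc(/C=C/C(=O)/C=C/c2ccc(OCc3cn(CCCOc4cc(=O)oc5ccccc45)nn3)c(OC)c2)cc1OC`, which in this assay gives 65%

Compound 1 holds the lower of the two numbers; compound 2 lies above it by a gap beyond the usual scatter, but the two differ in more than one place, so their values are only set side by side, not read as a single step. Compound 3 `COc1cc(/C=C/C(=O)/C=C/c2ccco2)ccc1OCc1cn(CCCCCOc2cc(=O)oc3ccccc23)nn1` differs from compound 1 by furan-2-yl in place of 3-methoxyphenyl on a double-bonded chain carbon bound to a double-bonded chain carbon. Going by the values given here, no measured pair isolates this change, so compound 3 is expected to show no step beyond the scatter, an estimated a number 1 percentage points higher from compound 1 to compound 3 (within the scatter). Compound 3 is therefore estimated at 35%, with a range from 15% to 58%.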

Compound 3, percent growth inhibition at one concentration: 33%
Compound 3: the middle estimate sits 2 percentage points above what was measured; the range from low to high includes it.
By their numbers in this assay, from the lowest: compounds 3 and 1 (each within the scatter of the next); then compound 2.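

In this assay, going by these compounds alone, furan-2-yl in place of 3-methoxyphenyl on a double-bonded chain carbon bound to a double-bonded chain carbon gives a number 1 percentage points lower from compound 1 to compound 3 (within the scatter), the first comparison that isolates a single place. At this position on the core of compound 1, the six-membered aromatic ring of carbon only and the five-membered aromatic ring with 1 hetero atom are therefore not told apart by this read-out. Nothing available explains why the two groups read alike. On these data alone, what an aminophenyl or a carboxylic acid group would give at this position remains open, as does whether the same swap reads alike on the chain of compound 2.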